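The source may report more compounds than this note shows. Statements on the series, on what has been measured and on what is new or still open speak of the compounds shown alone.

Working notes on the series. Compound 1 `Cc1ccc(-c2cnn3c(NCc4ccccn4)cc(C)nc23)cc1` is the reference. In a physicochemical assay for solubility, read by HPLC, using the shake flask method, measured as kinetic solubility, with a stated time of 2 h, at pH 7.4 (on this read-out lower numbers stand for lower solubility and higher numbers for higher solubility), compound 1 gives < 5000 nM, which is a limit of the assay and not a number. Compound 2 `Cc1cc(NCc2ccccn2)n2ncc(-c3ccc(F)cc3F)c2n1` carries 2,4-difluorophenyl in place of 4-methylphenyl on an aromatic carbon. In this assay compound 2 gives < 5000 nM, again a limit of the assay and not a number. The step that the two limits leave unreadable from compound 1 to compound 2 is therefore not readable, since the limit of < 5000 nM in this assay, at which 2 of the 2 values shown sit, holds both values shown.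

Compound 3 `Cc1cc(NCc2ccccn2)n2ncc(-c3ccc(C(=O)Nc4ccccc4)cc3)c2n1` has not yet been measured in this assay. It differs from compound 1 by phenylcarbamoyl in place of methyl on an aromatic carbon, at a site para to a large group. Going by the values given here, no measured step shares this change; the only measured step is the unreadable one from compound 1 to compound 2, so no size of effect can be drawn from it.

With compound 1 sitting at a limit in this assay, compound 3 is expected to return a limit as well; the estimate for compound 3 is 1000 nM, ranging from 150 nM to 5000 nM. This estimate implies a step that the limit leaves unreadable from compound 1 to compound 3, resting on a limit, and is expected to be of uncertain size.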

Compound 3, solubility: 5000 nM
For compound 3 the middle estimate is 5.0-fold (0.70 log units) below the measured one; measured number inside the range.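

Going by these compounds alone, at the site on the six-membered aromatic ring para to a large group, phenylcarbamoyl in place of methyl gives the first value in this assay that is a number and not a limit, so this position can carry a far larger group than methyl and still return a number. The change reads as a number no lower from compound 1 to compound 3 (the limit leaves the size open), which fixes only a direction and cannot be turned into a size. Compound 3 therefore holds the only number in the series, and the other two values remain limits of the assay: the limit of < 5000 nM in this assay, at which 2 of the 3 values shown sit.

From the compounds shown here alone, the size of the step for this change cannot be read, nor can the step for the 2,4-difluorophenyl change, so how far compound 3 stands from compound 1 remains open. Within the data shown here, also open is which part of phenylcarbamoyl carries the result, and whether a carboxylic acid, an amine or a simple unsubstituted carboxamide at this same site would return a number in this assay, and how that number would compare with the one for compound 3.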